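Acyl variation on the shared core: estimate for compound 4

The source may hold more compounds than are shown below. What is called first, only, known or untested is meant among the compounds shown, and "the series" means these compounds.

Compound 1, `CC(C)C(=O)N1CC2CC(C1)N2`, in an assay on CHO cells for displacement of a labelled ligand from Neuronal acetylcholine receptor; alpha3/alpha6/beta2/beta3 (Homo sapiens), read by scintillation counting; on this read-out higher numbers stand for weaker inhibition and lower numbers for stronger inhibition: 580 nM
Compound 2, `O=C(C1CCCC1)N1CC2CC(C1)N2`, in this assay: 2900 nM
Compound 3, `O=C(C1CC=CC1)N1CC2CC(C1)N2`, in this assay: 1100 nM

Compound 1 carries the lowest number of the three. Compound 3 sits within the scatter of it, so no order between compound 1 and compound 3 can be read. Compound 2 lies beyond the scatter, with a clearly higher number than compound 1. For the measured compounds named here, no pair of measured compounds differs in a single place, so no measured step is available.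

Compound 4, `O=C([C@@H]1C[C@@H]1F)N1CC2CC(C1)N2`, differs from compound 1 by 2-fluorocyclopropyl in place of isopropyl on a carbonyl carbon. Going by the values given here, the measured set gives no direct guide for this change; the only acyl groups with a ring, in compound 2 and compound 3, are both larger five-membered rings, and their comparison with compound 1 is not a single-change step. The expected step from compound 1 to compound 4 in this assay is a 1.6-fold higher number from compound 1 to compound 4 (0.19 log units; within the scatter), small and likely within the scatter, with any drift toward a higher number. For compound 4 the estimate in this assay is 900 nM, with a range from 300 nM to 3000 nM.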

Compound 4, inhibition constant: 55 nM
Beside the measured number, compound 4's estimate is 16-fold (1.21 log units) above it, and the stated range ends above it.
By their numbers in this assay, from the lowest: compound 4; then compounds 1 and 3 (each within the scatter of the next); then compound 2.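

In this assay, the acyl group on this carbonyl carbon proves to have a strong hold on the read-out: 2-fluorocyclopropyl in place of isopropyl gives an 11-fold lower number from compound 1 to compound 4 (1.02 log units; beyond the scatter). For the compounds shown here, the earlier compounds offered no single-change step at this position, so this is the first measured indication of how far a change there can move the number. Nothing shown accounts for the size of this step, and its cause stays unassigned.

The step brings in the three-membered ring, the fluorine and two defined stereocentres together, and a plain cyclopropyl group on the same carbonyl carbon would be needed to separate the share of the ring from that of the fluorine. Going by these compounds, whether the other stereoisomers of 2-fluorocyclopropyl give a similar number also remains open.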